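A Fluoro Added to the Core of Compound 1

The compounds below may be only part of what the source reports. "The series", "measured", "known", "first", "only" and "open" are said of these compounds alone.

Compound 1 `O=C1Nc2ccccc2/C1=C/c1ccc(-c2cn(-c3cccc(F)c3)nn2)cc1` has no exact potency on record in a functional assay on MKN-45 cells (Homo sapiens) for inhibition, read by CCK-8 assay, with a stated time of 24 h; on this read-out lower numbers stand for stronger inhibition and higher numbers for weaker inhibition. Compound 1 gives > 20000 nM, which is a limit of the assay and not a measured number. Compound 2 `N#Cc1cccc(-n2cc(-c3ccc(/C=C4\C(=O)Nc5ccccc54)cc3)nn2)c1` carries cyano in place of fluoro on an aromatic carbon. Compound 2 gives > 20000 nM, which is also a limit. All the data so far therefore come down to the limit of > 20000 nM in this assay, at which 2 of the 2 values shown sit.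

Compound 3 `O=C1Nc2ccc(F)cc2/C1=C/c1ccc(-c2cn(-c3cccc(F)c3)nn2)cc1` keeps the structure of compound 1 except for one change: fluoro in place of hydrogen on an aromatic carbon. In short, it has fluoro in place of hydrogen on an aromatic carbon. Among the measured compounds shown here, the only measured change is a step that the two limits leave unreadable from compound 1 to compound 2, so it offers no size to carry over to this new change. With no measured step to scale from, there is no firm reason to expect a shift in either direction in this assay. The estimated change is a number no higher from compound 1 to compound 3 (the limit leaves the size open), so no step beyond the scatter is expected, and another limit is the likeliest report. For compound 3 the estimated value is 20000 nM, with an expected range from 8000 nM to 40000 nM.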

Compound 3, half-maximal inhibitory concentration: 8190 nM
Compound 3: middle estimate off by 2.4-fold (0.39 log units), on the high side; measured number inside the range.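

In this assay, among the compounds shown here, fluoro in place of hydrogen on an aromatic carbon of the shared core gives an at least 2.4-fold lower number from compound 1 to compound 3 (0.38 log units; beyond the scatter), so this is the first change here with a readable direction. The earlier swap of cyano for fluoro cannot be read, as both of its values are limits, whereas this change, on a six-membered aromatic ring of carbon only that is part of a fused system of two rings, brings the series to an exact number. Compound 1 gives > 20000 nM, which is a limit of the assay and not a number, so the step has a smallest size but no known largest one, and the set still rests heavily on such limits: the limit of > 20000 nM in this assay, at which 2 of the 3 values shown sit.

It remains open whether this lower number is specific to fluoro or would also come with another group on the same carbon, such as chloro, methoxy or an amine, none of which is among the compounds shown. Going by these compounds, it is also open whether the same fluoro would give a similar step on compound 2, which carries cyano in place of the fluoro of compound 1.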